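The compounds below may be only part of what the source reports. "The series", "measured", "known", "first", "only" and "open" are said of these compounds alone.

Measured compounds:
- Compound 1 `CC(C)=CC[C@@H](OC(=O)C(C)C)C1=CC(=O)c2c(O)ccc(O)c2C1=O`: 84000 nM
- Compound 2 `C=CCCCCC(=O)O[C@H](CC=C(C)C)C1=CC(=O)c2c(O)ccc(O)c2C1=O`: 250000 nM

Among the compounds with values here, in an assay on HeLa cells for inhibition of DNA topoisomerase 1 (Homo sapiens) (a lower number here means a stronger inhibitor, a higher number a weaker inhibitor), compound 2 gives 250000 nM, the highest of the two numbers; its nearest neighbour is compound 1, and the step of a 3.0-fold higher number from compound 1 to compound 2 (0.47 log units; beyond the scatter), hex-5-en-1-yl in place of isopropyl on a carbonyl carbon, is the only measured step.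

Compound 3 `CCCCCCCCCCCCCCCC(=O)O[C@H](CC=C(C)C)C1=CC(=O)c2c(O)ccc(O)c2C1=O` differs from compound 2 by undecyl in place of vinyl on a saturated chain carbon, four bonds along the chain from a carbonyl carbon; cut one bond further out, the same difference reads allyl to dodecyl. Within the data shown here, the only step that bears on it is a 3.0-fold higher number from compound 1 to compound 2 (0.47 log units; beyond the scatter), where a longer acyl chain went with a modestly higher number, beyond the scatter. Among the measured compounds shown here, compound 3 carries the chain lengthening much further, with no measured precedent for that range, so the direction is taken from compound 1 to compound 2 and the size is uncertain. A further rise of similar size is expected, a 2.4-fold higher number from compound 2 to compound 3 (0.38 log units; beyond the scatter), with a real chance that this assay reports only a limit. Compound 3 is therefore estimated at 600000 nM in this assay, with a range from 150000 nM to 2500000 nM.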

Compound 3, half-maximal inhibitory concentration: > 625000 nM
Compound 3 ended at the assay's limit; the forecaster's own chance of this, stated with the estimate: 40%; at least 1.0-fold (0.01 log units) between middle value and limit.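

In this assay, the step with undecyl in place of vinyl on a saturated chain carbon, four bonds along the chain from a carbonyl carbon, is an at least 2.5-fold higher number from compound 2 to compound 3 (0.39 log units; beyond the scatter), and it runs the same way as a 3.0-fold higher number from compound 1 to compound 2 (0.47 log units; beyond the scatter). Compound 3 gives > 625000 nM, which is a limit of the assay and not a number. All three compounds therefore fall in one order along the acyl chain, with none going against it, but only the first step has a definite size, and the second is bounded on one side only: the limit of > 625000 nM in this assay, at which 1 of the 3 values shown sits.

Open, going by these compounds, is whether a shorter acyl group such as acetyl, or a chain ending in a carboxylic acid or an amine, would give a lower number than compound 1 at 84000 nM. Also open, on these data alone, is whether chain length alone tracks the number, since the terminal vinyl of compound 2 gives way to a saturated end in compound 3 in the same change, so the two cannot be separated here.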